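Hydroxymethyl in Place of Hydroxy: Compound 2 to Compound 4

The source may report more compounds than this note shows. Statements on the series, on what has been measured and on what is new or still open speak of the compounds shown alone.

compound 1 `N#Cc1ccc(OC[C@H]2CN(S(=O)(=O)c3ccc(Cl)cc3Cl)C[C@H]2O)cc1F` — 1500 nM
compound 2 `N#Cc1ccc(O[C@H]2CN(S(=O)(=O)c3ccc(Cl)cc3Cl)C[C@H]2O)cc1F` — 100 nM
compound 3 `N#Cc1ccc(O[C@H]2CN(S(=O)(=O)c3ccc(C(F)(F)F)cc3C#N)C[C@@]2(O)CO)cc1F` — 1 nM

All three measured values come from an assay on cells for antagonist activity at transient receptor potential cation channel subfamily V member 4 (Homo sapiens), read by FLIPR and calcium flux, with a stated time of 10 min; a higher number here means a weaker inhibitor, a lower number a stronger inhibitor. Compound 1 gives 1500 nM, compound 2 gives 100 nM, and compound 3 gives 1 nM. Among these three, compound 2 holds the middle place: compound 1 returns a higher number than compound 2, and compound 3 a lower one, and both gaps lie beyond the usual scatter.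

Compound 4 `N#Cc1ccc(O[C@H]2CN(S(=O)(=O)c3ccc(Cl)cc3Cl)C[C@H]2CO)cc1F` has not yet been measured. It differs from compound 2 in one place: hydroxymethyl in place of hydroxy on a saturated ring carbon. For the measured compounds named here, no pair of measured compounds differs in exactly this way, so the size of the step has no direct precedent here. Compound 3 carries a hydroxymethyl together with a hydroxy on the same saturated ring carbon, yet it also bears a different aryl group on the sulfonyl, so its low number cannot be credited to the hydroxymethyl alone. Without a direct comparison, the step in this assay is expected to be small, with no direction beyond the scatter, a 1.5-fold higher number from compound 2 to compound 4 (0.18 log units; within the scatter). Compound 4 is therefore estimated at 150 nM, within a range from 30 nM to 700 nM.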

Compound 4, half-maximal inhibitory concentration: 50 nM
Beside the measured number, compound 4's estimate is 3.0-fold (0.48 log units) above it; the range from low to high includes it.
By their numbers in this assay, from the lowest: compound 3; then compounds 4 and 2 (each within the scatter of the next); then compound 1.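

In this assay, for the compounds shown here, hydroxymethyl in place of hydroxy on this saturated ring carbon gives a 2.0-fold lower number from compound 2 to compound 4 (0.30 log units; within the scatter), the first direct reading of a change at this position with the rest of the molecule held constant. The ring carbon therefore accepts the hydroxymethyl, with its added carbon, without a shift beyond the usual scatter, although this one pair speaks only for the dichlorophenyl sulfonyl series of compound 2 and compound 4. Hydroxy and hydroxymethyl each count the same hydrogen-bond donors and acceptors, and no measurement is at hand that explains why this exchange leaves the reading within the scatter.

Going by these compounds, it remains open whether an amine, a carboxylic acid or a longer chain such as hydroxyethyl on the same ring carbon would also stay within the scatter of compound 2, or whether removing the oxygen altogether would matter. Also open, on these data alone, is what hydroxymethyl and hydroxy together on one ring carbon contribute, as compound 3, at 1 nM, differs from compound 4 in more than one place and cannot settle that question.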